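Indole series: amide-to-amine swap on compound 3

The source may hold more compounds than are shown below. What is called first, only, known or untested is meant among the compounds shown, and "the series" means these compounds.

Three compounds carry numbers. Compound 1 `CCNC(=O)c1c(CNCc2ccc(OC)cc2)c2ccccc2n1Cc1ccc(OC)cc1` gives 58900 nM in a functional assay on Bel-7402 cells (Homo sapiens) for antiproliferative activity, read by MTT assay, with a stated time of 72 h; a lower number here means a stronger inhibitor, a higher number a weaker inhibitor. Compound 2 `COc1cccc(CNCc2c(C(=O)O)n(Cc3ccccc3)c3ccccc23)c1` returns only a limit of this assay, recorded as > 50000 nM. Compound 3 `COc1ccc(Cn2c(C(=O)O)c(CNC(=O)c3cccc(OC)c3)c3ccc(C)cc32)cc1` also returns only a limit in this assay, recorded as > 50000 nM, so no number stands for it. Within the data shown here, its standing is therefore fixed by the limit of > 50000 nM in this assay, at which 2 of the 3 values shown sit: the series as measured is uniformly weak, and no single-change pair among the measured compounds exists, so nothing measured here tells how any one change moves this assay.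

Compound 4 `COc1ccc(Cn2c(C(=O)O)c(CN(C)Cc3cccc(OC)c3)c3ccc(C)cc32)cc1` differs from compound 3 by (3-methoxybenzyl)(methyl)amino in place of ((3-methoxyphenyl)carbonyl)amino on a saturated chain carbon bound to an aromatic carbon. Among the measured compounds shown here, with no measured step to lean on and every measured value at or near the limit, the step from compound 3 to compound 4 is expected to be small, an at least 1.2-fold lower number from compound 3 to compound 4 (0.09 log units; that floor lies within the scatter), and not clearly beyond the scatter. Compound 4 is accordingly estimated at 40000 nM in this assay, within 15000 nM to 100000 nM, with a fair chance that only a limit is reported again.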

Compound 4, half-maximal inhibitory concentration: 33000 nM
Compound 4: middle estimate off by 1.2-fold (0.08 log units), on the high side; low and high end bracket the measured number.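

Among these compounds, on the saturated chain carbon bound to an aromatic carbon, (3-methoxybenzyl)(methyl)amino in place of ((3-methoxyphenyl)carbonyl)amino gives the first step that can be read in this assay, an at least 1.5-fold lower number from compound 3 to compound 4 (0.18 log units; that floor lies within the scatter). Compound 3 is recorded only as a limit, > 50000 nM, so the step has a floor and no full size. The change removes the carbonyl and the amide hydrogen and brings in a methyl, yet the series as a whole stays weak: the limit of > 50000 nM in this assay, at which 2 of the 4 values shown sit.

The compounds shown do not separate the part played by the methyl from the part played by the loss of the carbonyl within this change. As far as these compounds go, whether a sulfonamide or a piperidine on this carbon would give a step beyond the scatter also remains open.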